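The compounds below may be only part of what the source reports. "The series", "measured", "known", "first", "only" and "open" are said of these compounds alone.

Measured so far in a functional assay on HeLa cells (Homo sapiens) for cytotoxicity, read by WST assay, with a stated time of 48 h; a lower number here means a stronger inhibitor, a higher number a weaker inhibitor:
compound 1 `CCCCCC/C=C/C[C@H]1C[C@@H]([C@@H](O)c2ccccc2)CO[C@@H]1c1ccccc1` gives 7400 nM
compound 2 `COc1ccc(/C=C/C[C@H]2C[C@@H]([C@@H](O)c3ccc(OC)c(OC)c3)CO[C@@H]2c2ccc(OC)c(OC)c2)cc1` gives 12200 nM
compound 3 `COc1ccc(/C=C/C[C@@H]2C[C@@H]([C@@H](O)c3ccc(OC)c(OC)c3)CO[C@H]2c2ccc(OC)c(OC)c2)cc1OC` gives 30600 nM

Compound 1 has the lowest of the three numbers. Its gap to compound 2 lies within the usual scatter of repeated measurements, so those two cannot be ordered against each other; its gap to compound 3 lies beyond the scatter. Compound 2 and compound 3 each differ from compound 1 at several places at once, so none of these pairs gives a single-change step whose size could be carried forward.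

Compound 4 `O=[N+]([O-])c1ccccc1/C=C/C[C@H]1C[C@@H]([C@@H](O)c2ccccc2)CO[C@@H]1c1ccccc1` is the compound still to be measured. It differs from compound 1 in one place: 2-nitrophenyl in place of hexyl on a double-bonded chain carbon bound to a double-bonded chain carbon. For the measured compounds named here, nothing measured so far isolates an exchange of this kind on the shared core, so there is no step of known size to lean on, and the expectation rests on compound 1 alone, with wide uncertainty. For compound 4 the expected value in this assay is 6000 nM, with a range from 2000 nM to 20000 nM. The step that this estimate means is a 1.2-fold lower number from compound 1 to compound 4 (0.09 log units; within the scatter), expected to stay within the scatter rather than to run clearly in either direction.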

Compound 4, half-maximal inhibitory concentration: 11800 nM
Compound 4: middle estimate off by 2.0-fold (0.29 log units), on the low side; measured number inside the range.
By their numbers in this assay, from the lowest: compounds 1, 4 and 2 (each within the scatter of the next); then compound 3.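

For the compounds shown here, exchanging hexyl for 2-nitrophenyl on a double-bonded chain carbon bound to a double-bonded chain carbon gives, in this assay, a 1.6-fold higher number from compound 1 to compound 4 (0.20 log units; within the scatter), the first single-change reading at this position on the shared core. An open chain and a substituted aromatic ring therefore cannot be told apart here by this read-out, although the entering group brings a six-membered aromatic ring and hydrogen-bond acceptors that hexyl lacks, so neither the chain nor the ring is shown to be required at this position for a number in this range. No measurement at hand accounts for this outcome.

Still open, as far as these compounds go, is whether a plain phenyl, an aminophenyl in place of the 2-nitrophenyl, a carboxylic acid or a chain longer than hexyl at this position would also stay within the scatter of compound 1 or would move the number clearly in either direction. Going by these compounds alone, also open is whether the exchange reads the same way on a core whose other aromatic rings carry different groups, since the only step available rests on the single pair of compound 1 and compound 4.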